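The source may hold more compounds than are shown below. What is called first, only, known or untested is meant among the compounds shown, and "the series" means these compounds.

Within the data shown here, in a functional assay on A549 cells (Homo sapiens) for antiproliferative activity, read by MTT assay, with a stated time of 72 h (a higher number here means a weaker inhibitor, a lower number a stronger inhibitor), compound 3 `O=C(Nc1cccc(I)c1)C(Cl)Cl` gives 4760 nM, the lowest of the three numbers so far; compound 2 `O=C(Nc1cccc(Br)c1)C(Cl)Cl` gives 7800 nM, and the two sit within the scatter of each other, whereas compound 1 `Cc1cccc(NC(=O)C(Cl)Cl)c1` gives 41100 nM. Compound 4 `COc1cccc(NC(=O)C(Cl)Cl)c1` differs from compound 3 by methoxy in place of iodo on an aromatic carbon. Among the measured compounds shown here, no measured step exchanges iodo for methoxy. For the measured compounds named here, the steps that bear on it are an 8.6-fold lower number from compound 1 to compound 3 (0.94 log units; beyond the scatter) and a 5.3-fold lower number from compound 1 to compound 2 (0.72 log units; beyond the scatter), in both of which the non-halogen partner carries the higher number; a 1.6-fold lower number from compound 2 to compound 3 (0.21 log units; within the scatter) adds nothing beyond the scatter. A higher number is therefore expected for compound 4, on the strength of an 8.6-fold lower number from compound 1 to compound 3 (0.94 log units; beyond the scatter), though its size is uncertain. For compound 4 the estimate is 20000 nM (range 6000 nM to 60000 nM), an expected step of a 4.2-fold higher number from compound 3 to compound 4 (0.62 log units; beyond the scatter).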

Compound 4, half-maximal inhibitory concentration: 25800 nM
The estimate for compound 4 lay 1.3-fold (0.11 log units) below the measured number; the range from low to high includes it.
By their numbers in this assay, from the lowest: compounds 3 and 2 (each within the scatter of the next); then compounds 4 and 1 (each within the scatter of the next).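

In this assay, methoxy in place of a halogen on this aromatic carbon costs activity: a 5.4-fold higher number from compound 3 to compound 4 (0.73 log units; beyond the scatter) and a 3.3-fold higher number from compound 2 to compound 4 (0.52 log units; beyond the scatter), both beyond the scatter. Methoxy does not separate from methyl, with a 1.6-fold lower number from compound 1 to compound 4 (0.20 log units; within the scatter) within the scatter, so among these four compounds only the bromo and iodo compounds stand apart. Nothing measured here explains this split. Still open, going by these compounds, is where an amine, a nitrile or a carboxylic acid at this carbon would fall. Whether chloro or fluoro would track with bromo and iodo also remains unanswered.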